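The source may hold more compounds than are shown below. What is called first, only, known or untested is meant among the compounds shown, and "the series" means these compounds.

Compound 3 `Oc1cc(C(F)(F)F)ccc1-c1nc(-c2ccccc2O)n(-c2ccc(C(F)(F)F)cc2)n1` is tested in a functional assay on PC-12 cells (Rattus norvegicus) for cytotoxicity, read by MTT assay, with stated times of 2 h and 24 h, tested at 1 uM (a lower number here means a weaker effect, a higher number a stronger effect of the compound at the concentration tested), and gives 70.7%. That is the highest of the three numbers measured, yet compound 2 `Oc1cc(C(F)(F)F)ccc1-c1nc(-c2ccccc2O)n(-c2ccc(I)cc2)n1` at 70.1% and compound 1 `Oc1cc(C(F)(F)F)ccc1-c1nc(-c2ccccc2O)n(-c2ccc(F)cc2)n1` at 67.2% sit so close that the gaps mean little: a number 0.6 percentage points higher from compound 2 to compound 3 (within the scatter), a number 3.5 percentage points higher from compound 1 to compound 3 (within the scatter), and a number 2.9 percentage points higher from compound 1 to compound 2 (within the scatter). All three of those steps swap the group on the same ring nitrogen and none moves the number beyond the scatter. Compound 4 `Oc1cc(C(F)(F)F)ccc1-c1nc(-c2ccccc2O)n(-c2ccccc2F)n1` follows the same pattern of change, with 2-fluorophenyl in place of 4-(trifluoromethyl)phenyl on an aromatic nitrogen. Because a number 3.5 percentage points higher from compound 1 to compound 3 (within the scatter) and a number 0.6 percentage points higher from compound 2 to compound 3 (within the scatter) stayed within the scatter, no step beyond it is expected here either, so compound 4 is expected to show a number 2.7 percentage points lower from compound 3 to compound 4 (within the scatter). The estimate for compound 4 is 68%, between 58% and 78%.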

Compound 4, a percentage reported as activity, at one concentration (the size of the read-out at that concentration, not a potency): 63.4%
The estimate for compound 4 lay 4.6 percentage points above the measured number, and the stated range covers the measured number.
By their numbers in this assay, from the lowest: compounds 4, 1, 2 and 3 (each within the scatter of the next).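

Within the data shown here, compound 4 is the first here to carry its halogen at the 2 position of the phenyl on the aromatic nitrogen, and moving fluoro there from the 4 position gives a number 3.8 percentage points lower from compound 1 to compound 4 (within the scatter). Replacing 4-iodophenyl or 4-(trifluoromethyl)phenyl with 2-fluorophenyl gives a number 6.7 percentage points lower from compound 2 to compound 4 (within the scatter) and a number 7.3 percentage points lower from compound 3 to compound 4 (within the scatter), so neither the group at the 4 position nor this shift takes any step beyond the scatter. Nothing available explains these small steps. On these data alone, whether an amine or a carboxylic acid on this phenyl ring would move the number beyond the scatter remains open.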